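The source may report more compounds than this note shows. Statements on the series, on what has been measured and on what is new or still open speak of the compounds shown alone.

Compound 1, `COc1ccc([C@H]2CC(=O)N(c3cc(N)cc(N)c3)C2)cc1OC1CCCC1`, was examined in a functional assay on HEK293 cells (Homo sapiens) for cytotoxicity; on this read-out lower numbers stand for higher toxicity in this test and higher numbers for lower toxicity in this test. In this assay compound 1 gives > 10000 nM, which is a limit of the assay and not a number. Among the compounds with values here, the only measured neighbour is compound 2, `COc1ccc([C@H]2CC(=O)N(c3ccccc3N)C2)cc1OC1CCCC1`. In this assay compound 2 gives > 10000 nM, again a limit of the assay rather than a number. The step that the two limits leave unreadable from compound 1 to compound 2 therefore cannot be read, and both values sit at the limit of > 10000 nM in this assay, at which 2 of the 2 values shown sit, so compound 1 stands on the non-toxic side of this test as far as the numbers go, with nothing finer known.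

Compound 3, `COc1ccc([C@H]2CC(=O)N(c3ccc(S(C)(=O)=O)cc3)C2)cc1OC1CCCC1`, differs from compound 1 by 4-(methylsulfonyl)phenyl in place of 3,5-diaminophenyl on an amide-type nitrogen in a ring. Within the data shown here, the one measured step with a change on the same nitrogen, a step that the two limits leave unreadable from compound 1 to compound 2, gives no readable size, so no direction beyond the scatter can be expected from it; the expectation rests on the fact that both measured values sit at the limit (the limit of > 10000 nM in this assay, at which 2 of the 2 values shown sit). The step that the limit leaves unreadable from compound 1 to compound 3 is therefore expected to be small. Compound 3 is estimated at 20000 nM in this assay, within the range 7000 nM to 60000 nM, most likely reported again only as a limit.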

Compound 3, half-maximal cytotoxic concentration: > 10000 nM
Compound 3: a limit, no number; the forecaster's own chance of this, stated with the estimate: 80%; the middle value is on the limit's open side.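

In this assay compound 3 gives > 10000 nM which is a limit of the assay and not a number. Within the data shown here, no step among compound 1, compound 2 and compound 3 can be read, with all values at one limit: the limit of > 10000 nM in this assay, at which 3 of the 3 values shown sit.

In this assay the compounds shown leave open whether 3,5-diaminophenyl, 2-aminophenyl and 4-(methylsulfonyl)phenyl on the amide-type nitrogen differ at all, none of the three compounds giving a number.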